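Swapping a Styryl Arm for a Dimethoxyphenyl Group

The compounds below may be only part of what the source reports. "The series", "measured", "known", "first", "only" and "open" are said of these compounds alone.

Compound 2 `Cc1cc(O)c(C2=NN(c3ccc(S(N)(=O)=O)cc3)C(/C=C/c3ccccc3)C2)cc1Cl` gives 34900 nM in a functional assay on UO-31 cells (Homo sapiens) for antiproliferative activity, with a stated time of 48 h (on this read-out lower numbers stand for stronger inhibition of growth and higher numbers for weaker inhibition of growth), the highest of the two numbers measured. Compound 1 `Cc1cc(O)c(C2=NN(c3ccc(S(N)(=O)=O)cc3)C(c3ccccc3Cl)C2)cc1Cl` gives 16200 nM in this assay, and the step of a 2.2-fold higher number from compound 1 to compound 2 (0.33 log units; beyond the scatter) shows that putting an ethenyl-linked phenyl onto that saturated ring carbon weakened growth inhibition modestly. Compound 3 `COc1ccc(C2CC(c3cc(Cl)c(C)cc3O)=NN2c2ccc(S(N)(=O)=O)cc2)cc1OC` reverses that idea: 3,4-dimethoxyphenyl in place of 2-phenylethenyl on a saturated ring carbon. For the measured compounds named here, since the only measured step shows a directly attached aryl giving a lower number, compound 3 is expected to return toward that level, roughly a 1.9-fold lower number from compound 2 to compound 3 (0.29 log units; within the scatter). The estimate for compound 3 is 18000 nM, plausibly between 8000 nM and 40000 nM.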

Compound 3, concentration for total growth inhibition: 100000 nM
Estimate against measurement, compound 3: 5.6-fold (0.74 log units) below; measured number above the stated range.
By their numbers in this assay, from the lowest: compound 1; then compound 2; then compound 3.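

The position does not simply favour a directly attached aryl ring: 3,4-dimethoxyphenyl gives a 2.9-fold higher number from compound 2 to compound 3 (0.46 log units; beyond the scatter), and also a 6.2-fold higher number from compound 1 to compound 3 (0.79 log units; beyond the scatter), so it inhibits growth less well than both the 2-phenylethenyl and the 2-chlorophenyl groups. Compound 1 and compound 3 both carry a directly attached aryl ring, so the groups on that ring matter here, not the direct attachment alone. No available measurement explains this loss.

From the compounds shown here alone, whether a phenyl ring carrying a dimethylamino group or a carboxylic acid on this saturated ring carbon would fall nearer compound 1 or compound 3 remains open.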